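Swapping methyl for 2-methoxyphenyl on a scaffold with low inhibition numbers

This account rests on a few compounds, and the source may have more. Where it says the series, first, only, none or still open, it means among the compounds named here.

Measured compounds so far:
- Compound 1, `CC(C)(C)c1cc2[nH]nc(N)c2c(=O)[nH]1`: 4%
- Compound 2, `COc1cccc(-c2cc3c(c(N)nn3C)c(=O)[nH]2)c1`: 1%
- Compound 3, `Cc1cc2nn(-c3ccccc3)c(N)c2c(=O)[nH]1`: 1%

All three compounds were tested in an assay on isolated protein for inhibition of RAC-beta serine/threonine-protein kinase (Homo sapiens), read by mobility shift assay, tested at 30 uM; on this read-out higher numbers stand for more inhibition at the one concentration tested (going by the name of the read-out) and lower numbers for less inhibition. Compound 3 gives 1% in this assay, level with compound 2 at the digits recorded; together these two sit at the lowest point of the three numbers, and the value of compound 1 lies within the usual scatter of both, so the three compounds cannot be told apart on these data. Every one of them shows only slight inhibition.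

Compound 4, `COc1ccccc1-c1cc2nn(-c3ccccc3)c(N)c2c(=O)[nH]1`, has not yet been measured in this assay. It differs from compound 3 in one place: 2-methoxyphenyl in place of methyl on an aromatic carbon. Compound 2 already carries a methoxyphenyl at the corresponding place of a closely related scaffold and gives 1%, so the three measured compounds offer no sign that such a change lifts inhibition.

Within the data shown here, with no step between measured compounds available, the expectation for compound 4 rests on the flat picture so far. Compound 4 is expected to give 3%, within a range from -5% to 15%. The step this implies, a number 2 percentage points higher from compound 3 to compound 4 (within the scatter), is expected to stay within the scatter, in no clear direction.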

Compound 4, a percentage reported as inhibition, at one concentration (the size of the read-out at that concentration, not a potency): 0%
The estimate for compound 4 lay 3 percentage points above the measured number, within the range that was stated.
By their numbers in this assay, from the lowest: compounds 4, 2, 3 and 1 (each within the scatter of the next).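

In this assay, among these compounds, placing 2-methoxyphenyl on this aromatic carbon in place of methyl gives a number 1 percentage points lower from compound 3 to compound 4 (within the scatter), the first comparison in this set in which only one place on the molecule changes. The new group brings a six-membered aromatic ring and a hydrogen-bond acceptor, yet the read-out stays within the usual scatter, so this change produces no detectable gain in inhibition on this core; with compound 3 already at 1%, there was also almost no room for a measurable loss. No available evidence bears on the reason for this flat outcome.

Still open, as far as these compounds go, is whether a different kind of group on this aromatic carbon, such as an amine, a carboxylic acid or a longer alkyl chain, would lift the number clearly beyond the scatter, or whether changes elsewhere on the core are needed before this position has any visible effect. With every compound tested at a single concentration and giving only slight inhibition, the data also cannot show whether this swap alters potency at all.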